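Methoxy for fluoro on the benzyl of a quinoxaline series

The source may hold more compounds than are shown below. What is called first, only, known or untested is meant among the compounds shown, and "the series" means these compounds.

Of the compounds shown here, three sharing one core have been measured in a functional assay on SF-295 cells (Homo sapiens) for inhibition, read by sulforhodamine B assay, with a stated time of 48 h; on this read-out lower numbers stand for stronger inhibition of growth and higher numbers for weaker inhibition of growth. Compound 1 `Nc1cc(N)c2nc(-c3ccccc3)c(NCc3ccc(Cl)c(Cl)c3)nc2c1` gives 15500 nM, compound 2 `COc1ccc(CNc2nc3cc(N)cc(N)c3nc2-c2ccccc2)cc1OC` gives 13200 nM, and compound 3 `Nc1cc(N)c2nc(-c3ccccc3)c(NCc3ccc(F)cc3)nc2c1` gives 3470 nM. Compound 3 has the lowest number of the three: the step of a 4.5-fold lower number from compound 1 to compound 3 (0.65 log units; beyond the scatter) and the step of a 3.8-fold lower number from compound 2 to compound 3 (0.58 log units; beyond the scatter) both lie beyond the scatter, whereas the step of a 1.2-fold lower number from compound 1 to compound 2 (0.07 log units; within the scatter) does not.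

Compound 4 `COc1ccc(CNc2nc3cc(N)cc(N)c3nc2-c2ccccc2)cc1` is not yet measured. It differs from compound 3 by methoxy in place of fluoro on an aromatic carbon. The step that bears most on this change is a 3.8-fold lower number from compound 2 to compound 3 (0.58 log units; beyond the scatter), where two methoxy groups gave way to a single fluoro; compound 4 restores one methoxy at the same position that bears the fluoro in compound 3, so part of that step is expected to be undone. Because a 1.2-fold lower number from compound 1 to compound 2 (0.07 log units; within the scatter) lay within the scatter, nothing in the data separates a methoxy-bearing benzyl from a chloro-bearing one.

Compound 4 is therefore expected to show a modest upward step, a 2.0-fold higher number from compound 3 to compound 4 (0.30 log units; within the scatter), in this assay. The estimate for compound 4 is 7000 nM, with a range from 3000 nM to 16000 nM.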

Compound 4, concentration for 50% growth inhibition: 17800 nM
The estimate for compound 4 lay 2.5-fold (0.41 log units) below the measured number; measured number outside the range, above it.
By their numbers in this assay, from the lowest: compound 3; then compounds 2, 1 and 4 (each within the scatter of the next).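

In this assay, the exchange of fluoro for methoxy on the aromatic carbon para to a large group proves enough on its own to remove the standing of compound 3 (a 5.1-fold higher number from compound 3 to compound 4 (0.71 log units; beyond the scatter)), so the earlier dimethoxy comparison did not depend on the presence of a second methoxy. That second methoxy makes no difference that can be read (a 1.3-fold higher number from compound 2 to compound 4 (0.13 log units; within the scatter)), and the 4-methoxyphenyl and 3,4-dichlorophenyl compounds also stay within the scatter of each other (a 1.1-fold higher number from compound 1 to compound 4 (0.06 log units; within the scatter)), which leaves compounds 1, 2 and 4 together and compound 3, with its 4-fluorophenyl, alone at the low end of the four. No measurement is available that would explain why fluoro and methoxy part at this place.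

What these compounds leave open is whether the low number belongs to fluoro in particular, since a plain unsubstituted benzyl, or a single chloro, a hydroxyl, an amine or a trifluoromethyl at the same place, could fall with compound 3 or with the other three. Whether a fluoro elsewhere on the ring, or two fluoro groups, would keep the low number also remains unanswered.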